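The source may hold more compounds than are shown below. What is called first, only, known or untested is meant among the compounds shown, and "the series" means these compounds.

Measured in a functional assay on DLD-1 cells (Homo sapiens) for inhibition, read by MTT assay, with a stated time of 72 h (on this read-out higher numbers stand for weaker inhibition and lower numbers for stronger inhibition), so far:
- compound 1 `COc1cc(Oc2cccc(Nc3ccccc3)c2)cc(OC)c1CNCc1ccc(F)cc1`: 2650 nM
- compound 2 `COc1cc(Oc2cccc(Nc3ccccc3)c2)cc(OC)c1CCO`: 18100 nM
- compound 3 `COc1cc(Oc2cccc(Nc3ccccc3)c2)cc(OC)c1CNC1CC1`: for compound 3 the result is a limit of the assay, > 20000 nM

Compound 3 thus stands at the floor of the set, at the limit (the limit of > 20000 nM in this assay, at which 1 of the 3 values shown sits). Its step from compound 1 reads an at least 7.5-fold higher number from compound 1 to compound 3 (0.87 log units; beyond the scatter), and from compound 2 it reads an at least 1.1-fold higher number from compound 2 to compound 3 (0.04 log units; that floor lies within the scatter).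

Compound 4 `COc1cc(Oc2cccc(Nc3ccccc3)c2)cc(OC)c1CNCc1ccc(Br)cc1` differs from compound 3 by 4-bromobenzyl in place of cyclopropyl on an amine nitrogen. Within the data shown here, the measured step that bears on this is the one from compound 1 to compound 3, an at least 7.5-fold higher number from compound 1 to compound 3 (0.87 log units; beyond the scatter), in which 4-fluorobenzyl gave way to cyclopropyl; compound 4 reverses that exchange, with a bromine rather than a fluorine on the benzyl. The step from compound 1 to compound 2, a 6.8-fold higher number from compound 1 to compound 2 (0.83 log units; beyond the scatter), likewise shows that losing the benzylamine raises the number. Among the measured compounds shown here, no measured pair separates a 4-bromobenzyl from a 4-fluorobenzyl, so that part of the change is unanchored. Relative to compound 3, compound 4 is expected to take a step of an at least 6.6-fold lower number from compound 3 to compound 4 (0.82 log units; beyond the scatter). In this assay compound 4 is estimated at 3000 nM, within a range of 1000 nM to 10000 nM.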

Compound 4, half-maximal inhibitory concentration: 3520 nM
Estimate against measurement, compound 4: 1.2-fold (0.07 log units) below; low and high end bracket the measured number.
By their numbers in this assay, from the lowest: compounds 1 and 4 (each within the scatter of the next); then compound 2. At a limit, above all of these: compound 3.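

Working notes on the series: in this assay, swapping the halogen on the benzyl leaves the two benzylamines reading alike, a 1.3-fold higher number from compound 1 to compound 4 (0.12 log units; within the scatter), so the fluoro result is not specific to fluorine, at least against bromo. The gain from a halogenated benzyl on the amine nitrogen now holds for a second member, with an at least 5.6-fold lower number from compound 3 to compound 4 (0.75 log units; beyond the scatter) against cyclopropyl and a 5.1-fold lower number from compound 2 to compound 4 (0.71 log units; beyond the scatter) against hydroxymethyl. Compound 3 remains a limit rather than a number, so its step is only a floor: the limit of > 20000 nM in this assay, at which 1 of the 4 values shown sits.

Going by these compounds, whether the halogen contributes at all remains open, since an unsubstituted benzyl or a methoxybenzyl would be needed to settle that. Also open, on these data alone, is how a longer chain such as phenethyl, or a second substituent making the amine tertiary, would read on that nitrogen.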